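Swapping Methyl for Pyridin-4-yl on a Bicyclic Core

The source may hold more compounds than are shown below. What is called first, only, known or untested is meant among the compounds shown, and "the series" means these compounds.

Compound 1 `CO[C@@H]1CC=C2NN(c3ccc(C)cc3)C(=O)C[C@]2(C)O1` is the starting point, and in a functional assay on DU-145 cells (Homo sapiens) for inhibition, read by sulforhodamine B assay, with a stated time of 48 h (a higher number here means a weaker inhibitor, a lower number a stronger inhibitor), compound 1 gives 23200 nM. Compound 2 `CO[C@@H]1CC=C2NN(c3ccc(C)cc3)C(=O)C[C@]2(c2ccncc2)O1` carries the change (pyridin-4-yl in place of methyl on a saturated ring carbon), and in this assay compound 2 gives 7100 nM, a step of a 3.3-fold lower number from compound 1 to compound 2 (0.51 log units; beyond the scatter). Compound 3 `COc1cc(OC)cc(N2NC3=CC[C@@H](OC)O[C@@]3(C)CC2=O)c1` has a different core; the difference between the two cores is not broken down here. In this assay compound 3 gives 22200 nM, which against compound 1 is within the scatter.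

Compound 4 `COc1cc(OC)cc(N2NC3=CC[C@@H](OC)O[C@@]3(c3ccncc3)CC2=O)c1` bears the same kind of change on the core of compound 3, (pyridin-4-yl in place of methyl on a saturated ring carbon). The surroundings are described differently: in compound 2 the carbon sits next to the ring oxygen, next to the ring atom that bears a fused ring, and two ring bonds from the ring atom that bears a methoxy group, whereas in compound 4 it is counted as two and three ring bonds from the ring nitrogen. Because the step of a 3.3-fold lower number from compound 1 to compound 2 (0.51 log units; beyond the scatter) was modest, a similar step a 3.0-fold lower number from compound 3 to compound 4 (0.47 log units; beyond the scatter) is expected. Compound 4 is therefore estimated at 7500 nM, with a range from 3500 nM to 16000 nM.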

Compound 4, half-maximal inhibitory concentration: 5900 nM
For compound 4 the middle estimate is 1.3-fold (0.10 log units) above the measured one; the range from low to high includes it.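

In this assay, the replacement of methyl by pyridin-4-yl on a saturated ring carbon gave a 3.8-fold lower number from compound 3 to compound 4 (0.58 log units; beyond the scatter). Set beside the earlier step, the change carries over between the two cores shown with no difference beyond the scatter: the same change on two cores in this assay, a 3.3-fold lower number (0.51 log units; beyond the scatter) from compound 1 to compound 2 and a 3.8-fold lower number (0.58 log units; beyond the scatter) from compound 3 to compound 4, 1.2-fold (0.06 log units) apart, within the scatter of two such steps. This shows that these two cores respond alike to this one replacement in this one cell assay, but it does not show why the number falls, nor that the same step would appear on any other core or in any other assay.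

What the compounds shown leave open is whether a phenyl or a pyridin-3-yl group on that saturated ring carbon would give a step of similar size, and whether an amine or a longer alkyl chain there would do the same. They also leave open whether the agreement between the two steps would hold on a third core.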